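The source may report more compounds than this note shows. Statements on the series, on what has been measured and on what is new or still open speak of the compounds shown alone.

Of the compounds shown here, three share one core and have been measured in an in vitro functional assay on HEK285-7 cells for antagonist activity at prostaglandin D2 receptor 2 (Homo sapiens), read by BRET and beta-arrestin recruitment; a higher number here means a larger maximal response, a lower number a smaller maximal response. Compound 1 `O=C(O)Cc1sc(C(c2ccc(F)cc2)c2ccc(F)cc2)nc1-c1ccccc1` gives 80%. Compound 2 `O=C(O)Cc1sc(C(c2ccccc2)c2ccc(F)c(F)c2)nc1-c1ccc(F)cc1` gives 80%, and compound 3 `COc1ccc(C(c2ccccc2)c2nc(-c3ccc(Cl)cc3)c(CC(=O)O)s2)cc1` gives 80%. These three values lie within the usual scatter of each other, so compound 1 stands level with compounds 2 and 3 in this assay, neither higher nor lower at the digits shown.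

Compound 4 `N#Cc1ccc(-c2nc(C(c3ccc(F)cc3)c3ccc(F)cc3)sc2CC(=O)O)cc1` is not yet measured. It differs from compound 1 in one place: cyano in place of hydrogen on an aromatic carbon. Since compounds 1, 2 and 3 carry different substituents on their outer rings yet all reach the same maximal response, no step beyond the scatter is expected here; the step of no change at the digits printed from compound 1 to compound 4 (within the scatter) is expected to be flat. Compound 4 is therefore estimated at 80%, within 68% to 92%.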

Compound 4, largest response reached (reported as efficacy), in percent of the reference or control that the assay uses: 30%
Beside the measured number, compound 4's estimate is 50 percentage points above it; measured number outside the range, below it.
By their numbers in this assay, from the lowest: compound 4; then compounds 1, 2 and 3 (each within the scatter of the next).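

In this assay, the change from phenyl to 4-cyanophenyl gives a number 50 percentage points lower from compound 1 to compound 4 (beyond the scatter), so one cyano group on this aromatic carbon, para to a large group, is enough to alter the maximal response strongly. The earlier compounds shown here differ from one another in more than one place, so they could not isolate this position. This pair does, and it shows that the position is sensitive to at least this change.

From the compounds shown here alone, whether the drop is specific to cyano stays open, and an amine or a carboxamide on the same carbon of compound 1 would help to answer that. Nothing shown here explains the drop.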